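Swapping iodo for amino in a cytotoxicity series

The compounds below may be only part of what the source reports. "The series", "measured", "known", "first", "only" and "open" are said of these compounds alone.

Compound 1 `Nc1nc2c(nc(I)n2COCCO)c(=O)[nH]1` gives 111000 nM as a number
Compound 2 `Nc1ncnc2c1ncn2C[C@@H]1C[C@H](CO)c2ccccc21` gives > 200000 nM as a limit
Compound 3 `O=c1ccn([C@@H]2O[C@H](CO)[C@H](F)[C@@H]2O)c(=O)[nH]1` gives > 200000 nM as a limit

Going by the values given here, in an ADME assay on L1210/0 cells (Mus musculus) for cytotoxicity, with a stated time of 48 h (a lower number here means a stronger inhibitor, a higher number a weaker inhibitor), compound 1 gives 111000 nM as the only true number of the three. Compound 2 and compound 3 reach only the limit of > 200000 nM in this assay, at which 2 of the 3 values shown sit, and give no number.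

Compound 4 `Nc1nc2c(nc(N)n2COCCO)c(=O)[nH]1` has not been measured yet. It carries amino in place of iodo on an aromatic carbon between two ring nitrogen atoms, next to the ring atom that bears a (2-hydroxyethoxy)methyl group. The rest of the core of compound 1 is kept. Among the compounds with values here, no measured pair here shows what such a swap does, so any expectation stays loose.

With compound 1 at 111000 nM as the sole anchor, a small step toward weaker inhibition in this assay is expected, perhaps none beyond the usual scatter. The estimated change is a 1.4-fold higher number from compound 1 to compound 4 (0.13 log units; within the scatter) on this reading. For compound 4 the expected value is 150000 nM with an estimated range from 50000 nM to 300000 nM around it.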

Compound 4, half-maximal inhibitory concentration: > 200000 nM
Compound 4: no number, only a limit; the forecaster's own chance of this, stated with the estimate: 50%; at least 1.3-fold (0.12 log units) between middle value and limit.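

In this assay, amino in place of iodo on an aromatic carbon between two ring nitrogen atoms gives an at least 1.8-fold higher number from compound 1 to compound 4 (0.25 log units; that floor lies within the scatter). Going by these compounds, that figure is only a floor set by a limit, so the true size of the step remains unknown: it could be small or much larger. This is still the first direct comparison at this position, and of the two compounds that differ here, only the iodo compound gives a true number, while the amino compound joins the others at the limit: the limit of > 200000 nM in this assay, at which 3 of the 4 values shown sit.

The compounds shown leave open whether a true number at this carbon is particular to iodo or would also appear with chloro, bromo or methyl. They also leave open how a plain hydrogen atom there would compare, which would show what iodo and amino each do against an unsubstituted carbon.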